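The compounds below may be only part of what the source reports. "The series", "measured", "known", "first", "only" and "open" are said of these compounds alone.

Working notes on the series. Compound 2 `CC(=O)N1N=C(c2cc(O)c(O)c([N+](=O)[O-])c2)CC1c1ccco1` is measured in an assay on isolated protein for inhibition of Amine oxidase [flavin-containing] A (Homo sapiens), read by fluorescence (a lower number here means a stronger inhibitor, a higher number a weaker inhibitor), at 98000 nM. Compound 1 `O=C(/C=C/c1ccoc1)c1cc(O)c(O)c([N+](=O)[O-])c1` gives 52900 nM and compound 3 `O=C(/C=C/c1cccs1)c1cc(O)c(O)c([N+](=O)[O-])c1` gives 49900 nM, both within the usual scatter of the number for compound 2, so no order among the three can be read. Compound 4 `CC(=O)N1N=C(c2cc(O)c(O)c([N+](=O)[O-])c2)CC1c1ccc(C#N)cc1` differs from compound 2 by 4-cyanophenyl in place of furan-2-yl on a saturated ring carbon. Going by the values given here, the only measured step on an aromatic group is a 1.1-fold lower number from compound 1 to compound 3 (0.03 log units; within the scatter), made on a different core, and it shows no movement beyond the scatter. Nothing measured touches the core of compound 2 or a cyanophenyl group. The expected step from compound 2 to compound 4 is therefore small, a 1.2-fold lower number from compound 2 to compound 4 (0.09 log units; within the scatter), with wide uncertainty. For compound 4 the estimate in this assay is 80000 nM, from 25000 nM to 250000 nM.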

Compound 4, half-maximal inhibitory concentration: 76600 nM
Beside the measured number, compound 4's estimate is 1.0-fold (0.02 log units) above it, within the range that was stated.
By their numbers in this assay, from the lowest: compounds 3, 1, 4 and 2 (each within the scatter of the next).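

On a saturated ring carbon of the core of compound 2, in this assay, 4-cyanophenyl in place of furan-2-yl gives a 1.3-fold lower number from compound 2 to compound 4 (0.11 log units; within the scatter) and stays within the scatter. Going by these compounds alone, this is the first step measured at this position and on this core, and it shows that a six-membered aromatic ring carrying a nitrile leaves the number where furan-2-yl had it. Nothing available explains this result. Open, going by these compounds, is whether an amine or a carboxylic acid at this position, or a longer chain in place of the acetyl group, would move the number beyond the scatter.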